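Chlorine to Fluorine at the Carbonyl-Bound Ring

This account rests on a few compounds, and the source may have more. Where it says the series, first, only, none or still open, it means among the compounds named here.

Compound 1 `COc1cc(-c2cc(/C=C/C(=O)c3ccc(Cl)c(Cl)c3)[nH]n2)cc(OC)c1OC` was tested in a functional assay on NCI/ADR-RES cells (Homo sapiens) for cytotoxicity, read by sulforhodamine B assay, with a stated time of 48 h, tested at 1 uM (on this read-out lower numbers stand for a stronger effect and higher numbers for a weaker effect at the one concentration tested), where compound 1 gives 92%. Among the measured compounds shown here, compound 2 `COc1ccc(-c2cc(/C=C/C(=O)c3ccc(N)cc3)[nH]n2)cc1`, the only other compound measured here, gives 85% in this assay. The two numbers lie within the usual scatter of each other, so neither compound can be set apart from the other on this read-out. For the measured compounds named here, no step between measured compounds that differ in a single place has been recorded, so nothing measured speaks directly to the change now considered.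

Compound 3 `COc1cc(-c2cc(/C=C/C(=O)c3ccc(F)c(F)c3)[nH]n2)cc(OC)c1OC` differs from compound 1 in one place: 3,4-difluorophenyl in place of 3,4-dichlorophenyl on a carbonyl carbon. Going by the values given here, no measured step bears on this exchange. The step expected from compound 1 to compound 3 in this assay is a number 1 percentage points higher from compound 1 to compound 3 (within the scatter), that is, none beyond the scatter in either direction. On that basis, compound 3 is estimated to give 93% in this assay, with a range from 80% to 105%.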

Compound 3, a percentage reported as activity, at one concentration (the size of the read-out at that concentration, not a potency): 95%
Compound 3: middle estimate off by 2 percentage points, on the low side, and the stated range covers the measured number.
By their numbers in this assay, from the lowest: compounds 2, 1 and 3 (each within the scatter of the next).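

Among the compounds shown here, the exchange of 3,4-dichlorophenyl for 3,4-difluorophenyl on a carbonyl carbon provides the first step between compounds differing in one place: in this assay the read-out is a number 3 percentage points higher from compound 1 to compound 3 (within the scatter) and lies within the scatter. On the core of compound 1, this pair of halogen-bearing phenyl groups therefore cannot be told apart at the one concentration tested. No measurement at hand accounts for this outcome.

From the compounds shown here alone, it remains open whether a carboxylic acid, a nitrile or a trifluoromethyl group on this phenyl ring would move the number beyond the scatter. Since compound 1 and compound 3 were compared at a single concentration, the read-out also leaves open whether the two would still be indistinguishable at any other concentration.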